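Ketone-side aryl swap: bromo to dimethyl

The source may hold more compounds than are shown below. What is called first, only, known or untested is meant among the compounds shown, and "the series" means these compounds.

Compound 1 `CCCC(C)Oc1ccc(C(=O)/C=C/c2c(/C=C/c3ccc(OC)cc3)cc(OC)cc2OC)cc1`, compound 2 `CCCCCCOc1ccc(C(=O)/C=C/c2c(/C=C/c3ccc(OC)cc3)cc(OC)cc2OC)cc1` and compound 3 `COc1ccc(/C=C/c2cc(OC)cc(OC)c2/C=C/C(=O)c2ccc(Br)cc2)cc1` share one core and differ only in the ring on the carbonyl carbon. In a functional assay on HepG2 cells (Homo sapiens) for antiproliferative activity, read by MTT assay, with a stated time of 48 h (on this read-out higher numbers stand for weaker inhibition and lower numbers for stronger inhibition), compound 1 gives 11.1 ug/mL, compound 2 gives 16.2 ug/mL and compound 3 gives 12.9 ug/mL; all three numbers lie within the scatter of one another, so no order among them is read. Compound 4 `COc1ccc(/C=C/c2cc(OC)cc(OC)c2/C=C/C(=O)c2ccc(C)cc2C)cc1` is not yet measured and differs from compound 3 by 2,4-dimethylphenyl in place of 4-bromophenyl on a carbonyl carbon. The steps that touch this same ring are a 1.2-fold higher number from compound 1 to compound 3 (0.07 log units; within the scatter) and a 1.3-fold lower number from compound 2 to compound 3 (0.10 log units; within the scatter), both within the scatter, so changes here have so far moved nothing. Compound 4 is therefore expected to give 13 ug/mL (range 7 ug/mL to 26 ug/mL), an estimated step of a 1.0-fold higher number from compound 3 to compound 4 (0.00 log units; within the scatter).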

Compound 4, half-maximal inhibitory concentration: 0.9 ug/mL
Compound 4: the middle estimate sits 14-fold (1.16 log units) above what was measured, and the stated range ends above it.
By their numbers in this assay, from the lowest: compound 4; then compounds 1, 3 and 2 (each within the scatter of the next).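

The ring on the carbonyl carbon is not a silent position: in this assay 2,4-dimethylphenyl brings a 14-fold lower number from compound 3 to compound 4 (1.16 log units; beyond the scatter) and a 12-fold lower number from compound 1 to compound 4 (1.09 log units; beyond the scatter) in the same read-out. Bromo, hexyloxy and 1-methylbutoxy on this ring had stayed within the scatter of one another, so this change alone separates one compound from the rest. No measurement shown here offers an explanation for the step.

Both methyl groups enter together, leaving open whether a single methyl group on the ring would carry the step. Also open, on these data alone, is whether ethyl or chloro groups in place of the two methyl groups would hold it.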